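The compounds below may be only part of what the source reports. "The series", "measured", "known", "first", "only" and "open" are said of these compounds alone.

Measured compounds:
compound 1, `CC[C@H](C)[C@H](N)CN(C(=O)[C@@H]1C[C@H]1c1ccccc1)c1ccc(-c2ccccc2)cc1`, in a functional assay for agonist activity at G protein-coupled receptor 88 (Homo sapiens), read by HTRF and cAMP accumulation; a higher number here means that more compound is needed for the effect, a lower number that less compound is needed: 230 nM; 800 nM (2 entries)
compound 2, `CC(C)CCNCCN(C(=O)[C@@H]1C[C@H]1c1ccccc1)c1ccc(-c2ccccc2)cc1`: 5.1 nM
compound 3, `CC(C)C[C@H](N)CN(C(=O)[C@@H]1C[C@H]1c1ccccc1)c1ccc(-c2cccs2)cc1`: 1500 nM

Compound 3 stands highest of the numbers shown in this assay, and its nearest neighbour, compound 2 at 5.1 nM, lies beyond the usual scatter; compound 1 is recorded twice, as the several entries of compound 1 in this assay, 230 nM; 800 nM (2 entries) shows, and so gives no single number to compare. Among the compounds with values here, no pair among the measured compounds differs in one place only, so no measured step is available. The step to compound 4, `Cc1ccc(-c2ccc(N(C[C@@H](N)CC(C)C)C(=O)[C@@H]3C[C@H]3c3ccccc3)cc2)cc1`, is 4-methylphenyl in place of thiophen-2-yl on an aromatic carbon. Compound 4 also shares its side chain with compound 3 and not with compound 1 or compound 2, so the comparison between compound 3 and compound 4 rests on the aryl change alone. The phenyl-bearing compounds 1 and 2 give lower numbers than compound 3, so a move toward the carbocyclic ring is expected to lower the number somewhat, by a 2.5-fold lower number from compound 3 to compound 4 (0.40 log units; beyond the scatter). Compound 4 is therefore estimated at 600 nM, with a range from 150 nM to 3000 nM.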

Compound 4, half-maximal effective concentration: 360 nM
Compound 4: the middle estimate sits 1.7-fold (0.22 log units) above what was measured; measured number inside the range.
By their numbers in this assay, from the lowest: compound 2; then compound 4; then compound 3.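

In this assay, within the data shown here, the aryl group on the six-membered aromatic ring of carbon only, para to a large group, now has a measured step with the side chain held fixed, a 4.2-fold lower number from compound 3 to compound 4 (0.62 log units; beyond the scatter), where the earlier compounds differed in more than one place. The change swaps a five-membered aromatic ring with 1 hetero atom for a six-membered aromatic ring of carbon only and also brings in the methyl, so this single step cannot divide its size among those differences. The data shown give no measured basis for explaining the step.

Open, on these data alone, is how much of the step belongs to the methyl, which a plain phenyl on the same side chain would separate from the ring change. Also open, as far as these compounds go, is how this position would respond to a carboxylic acid or an amine in place of the methyl, and whether the step would hold with the side chain of compound 2.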